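The source may hold more compounds than are shown below. What is called first, only, known or untested is meant among the compounds shown, and "the series" means these compounds.

Working notes on the series in a functional assay for inhibition of nuclear factor NF-kappa-B complex (Homo sapiens); on this read-out higher numbers stand for weaker inhibition and lower numbers for stronger inhibition.

Compound 1, `COc1ccc2c(c1)OC(c1cc(OC)c(OC)c(OC)c1)C(CO)=C2`, is the parent of the set. In this assay compound 1 gives only a limit of the assay, > 50000 nM, and no number. Among the measured compounds shown here, compound 2, `CCOCC1=Cc2ccc(OC)cc2OC1c1cc(OC)c(OC)c(OC)c1`, carries ethyl in place of hydrogen on an oxygen on a saturated carbon and is the only member with a measured number: in this assay compound 2 gives 21300 nM. For the measured compounds named here, the one measured step is an at least 2.3-fold lower number from compound 1 to compound 2 (0.37 log units; beyond the scatter); it is read against (the limit of > 50000 nM in this assay, at which 1 of the 2 values shown sits), so only its lower bound is known.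

Compound 3, `COc1ccc2c(c1)OC(c1cc(OC)c(OC)c(OC)c1)C(C(=O)OC(C)(C)C)=C2`, is not yet measured. Relative to compound 2 the change is tert-butoxycarbonyl in place of ethoxymethyl on a double-bonded ring carbon. Going by the values given here, no measured step alters this double-bonded ring carbon in a comparable way; the step from compound 1 to compound 2 only shows that a larger ether at that position is compatible with measurable inhibition. The expectation for compound 3 is therefore a step of a 1.1-fold lower number from compound 2 to compound 3 (0.03 log units; within the scatter), with no change beyond the scatter as the central case. Compound 3 is estimated at 20000 nM, with a range from 5000 nM to 60000 nM.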

Compound 3, half-maximal inhibitory concentration: 14100 nM
The estimate for compound 3 lay 1.4-fold (0.15 log units) above the measured number; the range from low to high includes it.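

In this assay, the double-bonded ring carbon of the shared core accepts tert-butoxycarbonyl as well as ethoxymethyl, and the exchange gives a 1.5-fold lower number from compound 2 to compound 3 (0.18 log units; within the scatter). Compound 2 and compound 3 therefore read as alike, so a group with 7 heavy atoms and a carbonyl in place of an ether chain with 4 heavy atoms leaves the read-out unchanged within the scatter. Replacing the hydroxymethyl of compound 1 gives an at least 3.5-fold lower number from compound 1 to compound 3 (0.54 log units; beyond the scatter), a second step beyond the scatter, though it too yields only a lower bound, as compound 1 gives a limit of the assay and no number: the limit of > 50000 nM in this assay, at which 1 of the 3 values shown sits.

The compounds shown do not separate the contribution of the carbonyl from that of the tert-butyl part, and a carboxylic acid, a methyl ester, an amide or an aminomethyl group at this carbon would be needed to tell these apart. From the compounds shown here alone, all three compounds also keep the same group on the ring atom that bears a large group, so how the changes at the double-bonded ring carbon depend on that group remains open, as does whether any change here can reach numbers well beyond those of compound 2 and compound 3.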